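The source may report more compounds than this note shows. Statements on the series, on what has been measured and on what is new or still open speak of the compounds shown alone.

Compound 1, `O=C(Nc1ccc(F)cc1F)c1cc(=O)[nH]c2cc(Br)ccc12`, in a functional assay on KYSE-410 cells (Homo sapiens) for antiproliferative activity, read by MTT assay, with a stated time of 72 h (on this read-out higher numbers stand for weaker inhibition and lower numbers for stronger inhibition), gives > 20000 nM, which is a limit of the assay rather than a number.
Compound 2, `O=C(Nc1ccc(F)cc1)c1cc(=O)[nH]c2cc(Br)ccc12`, in this assay gives > 20000 nM, again a limit of the assay.
Compound 3, `O=C(Nc1cc(F)c(F)c(F)c1)c1cc(=O)[nH]c2cc(Br)ccc12`, in this assay gives > 20000 nM, also a limit of the assay.

All three measured compounds share the same core, and each of them sits at the same limit in this assay, as the limit of > 20000 nM in this assay, at which 3 of the 3 values shown sit, records. The change from compound 1 to compound 2 is hydrogen in place of fluoro on an aromatic carbon, and the step it makes in this assay is a step that the two limits leave unreadable from compound 1 to compound 2. The difference between the core of compound 3 and that of compound 1 is not broken down here.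

Compound 4, `O=C(Nc1cc(F)cc(F)c1)c1cc(=O)[nH]c2cc(Br)ccc12`, has not yet been measured in this assay. It differs from compound 3 by hydrogen in place of fluoro on an aromatic carbon. This is the same kind of change as that from compound 1 to compound 2, though the surroundings differ: in compound 1 the fluoro that leaves stands ortho to a large group and meta to a fluoro group, whereas in compound 3 it stands ortho to two fluoro groups and para to a large group. Since compound 1, compound 2 and compound 3 all sit at the limit described in the limit of > 20000 nM in this assay, at which 3 of the 3 values shown sit, the step from compound 3 to compound 4 is expected to be a step that the limit leaves unreadable from compound 3 to compound 4, with its size unreadable if compound 4 also lands at the limit. Compound 4 is therefore estimated to give 30000 nM in this assay, with the range 10000 nM to 100000 nM, and most likely only a limit will be reported.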

Compound 4, half-maximal inhibitory concentration: 11200 nM
Compound 4: the middle estimate sits 2.7-fold (0.43 log units) above what was measured, within the range that was stated.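

In this assay, hydrogen in place of fluoro on an aromatic carbon, at the place ortho to two fluoro groups and para to a large group, gives an at least 1.7-fold lower number from compound 3 to compound 4 (0.25 log units; that floor lies within the scatter), and compound 4 is the only compound shown whose value is a number rather than a limit. The same kind of change on the core of compound 1 cannot be read, as the values of compound 1 and compound 2 are both limits of the assay, so there is no second size to set beside the new step. The result therefore does not show that the change carries from one core to another, nor that it fails to, and it does not establish a real gain, as the floor of the new step lies within the scatter and nearly all values shown remain at one limit: the limit of > 20000 nM in this assay, at which 3 of the 4 values shown sit.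

The compounds shown leave open whether a ring carrying no fluoro at all would give a readable value in this assay, and whether any fluoro pattern can move a value clearly beyond the scatter. They also leave open what an amine or a carboxylic acid on that ring would do, or a longer chain in place of the amide hydrogen.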